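Swapping the Benzyl Group on a Shared Nucleoside Core

This account rests on a few compounds, and the source may have more. Where it says the series, first, only, none or still open, it means among the compounds named here.

Compound 1, `OC[C@H]1O[C@@H](n2cnc3c(NCc4ccc(Br)cc4)ncnc32)[C@H](O)[C@@H]1O`, reaches only a limit in a functional assay on MCF cells (Homo sapiens) for antiproliferative activity, with a stated time of 72 h; on this read-out lower numbers stand for stronger inhibition and higher numbers for weaker inhibition: > 166000 nM.
Compound 2, `OC[C@H]1O[C@@H](n2cnc3c(NCc4ccc(F)c(F)c4F)ncnc32)[C@H](O)[C@@H]1O`, likewise reaches only a limit: > 166000 nM.
Compound 3, `OC[C@H]1O[C@@H](n2cnc3c(NCc4ccc(F)cc4Cl)ncnc32)[C@H](O)[C@@H]1O`, also reaches only a limit: > 166000 nM.

All three compounds share the same core and differ only in the aryl group on a saturated chain carbon bound to a nitrogen on an aromatic ring. None of them gave a number in this assay; each result is a limit, so the steps between them cannot be read: a step that the two limits leave unreadable from compound 1 to compound 2, a step that the two limits leave unreadable from compound 1 to compound 3 and a step that the two limits leave unreadable from compound 2 to compound 3 all stay unreadable. This is summed up by the limit of > 166000 nM in this assay, at which 3 of the 3 values shown sit. Compound 3 therefore stands at the same limit as compounds 1 and 2, with no ordering possible among them.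

Compound 4, `COc1cccc(CNc2ncnc3c2ncn3[C@@H]2O[C@H](CO)[C@@H](O)[C@H]2O)c1O`, carries the change (2-hydroxy-3-methoxyphenyl in place of 2-chloro-4-fluorophenyl on a saturated chain carbon bound to a nitrogen on an aromatic ring). Going by the values given here, no measured step bears on this change, since every step among compounds 1 to 3 is hidden by the limit. With three inactive neighbours and nothing pointing the other way, compound 4 is expected to end near the same limit, so the expected step of a number no higher from compound 3 to compound 4 (the limit leaves the size open) is essentially none beyond the scatter. The estimate for compound 4 in this assay is 166000 nM, ranging from 40000 nM to 500000 nM.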

Compound 4, half-maximal inhibitory concentration: 20200 nM
Beside the measured number, compound 4's estimate is 8.2-fold (0.91 log units) above it, outside the stated range (below it).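

Until now this position on the shared core had given only limits, so nothing showed that the aryl group on the saturated chain carbon could change the result in this assay at all, and the steps among compounds 1, 2 and 3 still cannot be read. Going by these compounds alone, putting 2-hydroxy-3-methoxyphenyl at this position gives a measurable number for the first time, with an at least 8.2-fold lower number from compound 3 to compound 4 (0.91 log units; beyond the scatter), an at least 8.2-fold lower number from compound 2 to compound 4 (0.91 log units; beyond the scatter) and an at least 8.2-fold lower number from compound 1 to compound 4 (0.91 log units; beyond the scatter), and each of these sizes is only a minimum, as the starting compound in each step sits at a limit. So this position does respond to the aryl group, and among the four compounds shown, only the one with a hydroxy and a methoxy group, rather than halogens, leaves the limit: the limit of > 166000 nM in this assay, at which 3 of the 4 values shown sit.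

The hydroxy and methoxy groups enter together in compound 4, so the compounds shown cannot tell whether one of them alone would give the same step, or whether both are needed. From the compounds shown here alone, it also stays open what an amine or a carboxylic acid on the phenyl ring would give at this position.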